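Compound 3 and its unmeasured neighbour, compound 4

This account rests on a few compounds, and the source may have more. Where it says the series, first, only, none or still open, it means among the compounds named here.

Four compounds are compared in a physicochemical assay for solubility, in phosphate buffer, at pH 7.4 (a higher number here means a more soluble compound, a lower number a less soluble compound), as follows:
compound 1 `CC(=O)N[C@@H]1CCC[C@H](C(=O)Nc2cc(-c3cnc(C)n3C(C)C)ccn2)C1` gives 660000 nM
compound 2 `CC(=O)N[C@@H]1CCC[C@H](C(=O)Nc2cc(-c3cnn4c3CCCC4)ccn2)C1` gives 730000 nM
compound 3 `CC(=O)N[C@@H]1CCC[C@H](C(=O)Nc2cc(-c3cnc4ccccn34)c(Cl)cn2)C1` gives 120000 nM
compound 4 `CC(=O)N[C@@H]1CCC[C@H](C(=O)Nc2cc(-c3cnn4c3NCCC4)c(Cl)cn2)C1` has not yet been measured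

Compound 3 holds the lowest of the three numbers, and its gaps to compound 1 and to compound 2 both lie beyond the scatter. Compound 4 differs from compound 3 by one exchange a group of 9 heavy atoms (6 carbon, 3 nitrogen; one five-membered aromatic ring with 2 hetero atoms, one six-membered non-aromatic ring with 2 hetero atoms) in place of a group of 9 heavy atoms (7 carbon, 2 nitrogen; one five-membered aromatic ring with 2 hetero atoms, one six-membered aromatic ring with 1 hetero atom), on an aromatic carbon and the place of this exchange is ortho to a chloro group.

For the measured compounds named here, only one measured step bears on this, and only loosely. It is a 1.1-fold higher number from compound 1 to compound 2 (0.04 log units; within the scatter) and it introduces a group with one five-membered aromatic ring with 2 hetero atoms and one six-membered non-aromatic ring with 1 hetero atom. Going by the values given here, no measured step starts from compound 3, and neither compound 1 nor compound 2 carries the chloro group.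

The entering group most resembles that of compound 2 (at 730000 nM) so a moderate rise is expected. The expected change is a 2.1-fold higher number from compound 3 to compound 4 (0.32 log units; beyond the scatter) and this estimate is uncertain. In this assay compound 4 is estimated at 250000 nM with an expected range from 100000 nM to 600000 nM as its likely span.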

Compound 4, solubility: 860000 nM
For compound 4 the middle estimate is 3.4-fold (0.54 log units) below the measured one, outside the stated range (above it).
By their numbers in this assay, from the lowest: compound 3; then compounds 1, 2 and 4 (each within the scatter of the next).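

In this assay, the exchange on the aromatic carbon ortho to a chloro group gives a 7.2-fold higher number from compound 3 to compound 4 (0.86 log units; beyond the scatter), so a change at this position can move the read-out beyond the scatter. The earlier step at the same position, on the core without the chloro group, gave a 1.1-fold higher number from compound 1 to compound 2 (0.04 log units; within the scatter), and so had shown no such movement. Here the leaving group has a six-membered aromatic ring with 1 hetero atom and no hydrogen-bond donor, while the entering group has a six-membered non-aromatic ring with 2 hetero atoms and a hydrogen-bond donor, but nothing at hand tells which of these differences accounts for the step, or why it occurs.

The compounds shown include no pair that differs only in the chloro group, so they leave open what that group contributes and whether the same exchange would give a similar step on the core without it. They also leave open how a fluoro or methyl group in place of the chloro group, or a morpholine ring at the position of the exchange, would read in this assay.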